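Two methyl groups added to the phenyl of compound 1

The compounds below may be only part of what the source reports. "The series", "measured", "known", "first", "only" and "open" are said of these compounds alone.

Among the compounds with values here, compound 1, `CC1CCC(=NNc2ccccc2)c2ncc(C(=O)O)c(=O)n21`, has been tested in a functional assay on the whole organism with Rattus norvegicus as the target; a lower number here means that less compound is needed, a higher number that more compound is needed for the effect; in this assay compound 1 gives 1.2 umol/kg, the only definite number among the values recorded so far. Compound 2, `CC1CCC(=NNc2ccccc2)c2ncc(C(=O)NO)c(=O)n21`, differs from it in a single place, carrying hydroxyamino in place of hydroxy on a carbonyl carbon. For compound 2 the assay returned only a limit, > 100 umol/kg, and not a number. That value is the limit of > 100 umol/kg in this assay, at which 1 of the 2 values shown sits. Within the data shown here, the single measured step, an at least 83-fold higher number from compound 1 to compound 2 (1.92 log units; beyond the scatter), therefore concerns a change at the carbonyl carbon alone.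

Compound 3, `Cc1cccc(NN=C2CCC(C)n3c2ncc(C(=O)O)c3=O)c1C`, keeps the hydroxy group of compound 1 and alters a different part of the molecule: 2,3-dimethylphenyl in place of phenyl on an amine nitrogen. Among the measured compounds shown here, no measured step touches that part, so nothing on hand points to a move beyond the scatter in either direction. Compound 3 is accordingly expected to give about 1.5 umol/kg, between 0.4 umol/kg and 6 umol/kg. That amounts to an expected step of a 1.3-fold higher number from compound 1 to compound 3 (0.10 log units; within the scatter).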

Compound 3, dose for 50% inhibition: > 100 umol/kg
Compound 3 ended at the assay's limit; the forecaster's own chance of this, stated with the estimate: 10%; middle value at least 66-fold (1.82 log units) from the limit.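

The phenyl on the amine nitrogen proves far from a free place to change: 2,3-dimethylphenyl in its stead gives an at least 83-fold higher number from compound 1 to compound 3 (1.92 log units; beyond the scatter). In this assay compound 3 gives > 100 umol/kg, which is a limit of the assay and not a number. So the hydroxy group on the carbonyl carbon, kept here, is not enough on its own to hold the number low, and a change far from that carbonyl now counts as well, with compound 3 joining compound 2: the limit of > 100 umol/kg in this assay, at which 2 of the 3 values shown sit.

On these data alone, what a single methyl group, a chloro group or a methoxy group on that phenyl would do remains open, as does whether one methyl group alone could account for the step. Compound 2 and compound 3 both rest on a limit, so no order between them can be read.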